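A few compounds are considered here, and "the series" means these few. Any claim that something is new, unique, unknown or untested is made for them only; others in the source may bear on it.

Three compounds have been measured in a physicochemical assay for metabolic stability, read by HPLC; a higher number here means that the compound lasts longer, a lower number that the compound disappears faster:

- Compound 1 (`O=c1ccn([C@H]2CC[C@@H](COP(=O)(O)Oc3ccccc3)O2)c(=O)[nH]1`): 25.1 h
- Compound 2 (`Cc1cn([C@H]2C[C@H](N=[N+]=[N-])[C@@H](COP(=O)(O)Oc3ccc(C#N)cc3)O2)c(=O)[nH]c1=O`): 7.08 h
- Compound 3 (`Nc1ncnc2c1ncn2[C@H]1CC[C@@H](COP(=O)(O)Oc2ccccc2)O1`): 36.1 h

Compound 2 stands lowest of the three. Compound 1 gives 25.1 h and compound 3 gives 36.1 h, and each of these lies beyond the scatter above the value of compound 2. The half-life of compound 2, 7.08 h, is therefore the short end of the measured range.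

The next compound to be measured is compound 4 (`Cc1cn([C@H]2C[C@H](N=[N+]=[N-])[C@@H](COP(=O)(O)Oc3cccnc3Cl)O2)c(=O)[nH]c1=O`), which is compound 2 with one change: 2-chloropyridin-3-yl in place of 4-cyanophenyl on an oxygen. In words, 2-chloropyridin-3-yl stands in place of 4-cyanophenyl on an oxygen, and the rest of the structure stays the same.

For the measured compounds named here, no two measured compounds differ in only one place, so the data give no measured size for a change of this kind, and any forecast is a judgement with a wide range. A moderate fall in half-life is expected rather than a rise, though one within the scatter cannot be ruled out. In this assay the expected change is a 1.8-fold lower number from compound 2 to compound 4 (0.25 log units; within the scatter).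

For compound 4 the estimated half-life is 4 h, with an expected range from 1.5 h to 10 h.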

Compound 4, half-life: 16.3 h
The estimate for compound 4 lay 4.1-fold (0.61 log units) below the measured number; measured number above the stated range.
By their numbers in this assay, from the lowest: compound 2; then compounds 4, 1 and 3 (each within the scatter of the next, the first and the last beyond it).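

In this assay, the group on an oxygen whose other neighbours are phosphorus turns out to matter on its own: 2-chloropyridin-3-yl in place of 4-cyanophenyl gives a 2.3-fold higher number from compound 2 to compound 4 (0.36 log units; beyond the scatter), a modest step but one beyond the scatter. Compounds 1, 2 and 3 differ from one another in more than one place, so they could not show this; here the rest of the structure stays the same and the group on this oxygen alone accounts for the difference between the two compounds. Nothing measured on these compounds speaks to the reason for the step, which stays unexplained.

The step replaces the carbon-only ring with a ring holding a hetero atom, adds a chlorine and removes the nitrile all at once, so the compounds shown leave open which of these carries it; a phenyl carrying a chlorine, or a pyridine ring without chlorine, on the same oxygen would pull them apart. Also open, as far as these compounds go, is whether the same exchange gives a step of like size on the cores of compound 1 and compound 3, which carry a plain phenyl at this oxygen.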